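The source may hold more compounds than are shown below. What is called first, only, known or untested is meant among the compounds shown, and "the series" means these compounds.

In an ADME assay on MT4 cells (Homo sapiens) for cytotoxicity (on this read-out higher numbers stand for lower toxicity in this test and lower numbers for higher toxicity in this test), compound 1 (`COC(=O)N[C@H](C(=O)NN(CCC[C@@](O)(Cc1ccccc1)C(=O)N[C@H]1c2ccccc2C[C@H]1O)Cc1ccccc1)C(C)(C)C`) gives > 10000 nM as a limit of the assay, not a number. Compound 2 (`COC(=O)N[C@H](C(=O)NN(CCC[C@@](O)(Cc1ccccc1)C(=O)N[C@H]1c2ccccc2C[C@H]1O)Cc1ccc(F)cc1)C(C)(C)C`) gives > 10000 nM and this too is only a limit. Compound 3 (`COC(=O)N[C@H](C(=O)NN(CCC[C@@](O)(Cc1ccccc1)C(=O)N[C@H]1c2ccccc2C[C@H]1O)Cc1ccc(Cl)cc1)C(C)(C)C`) carries chloro in place of fluoro on an aromatic carbon. Among the compounds with values here, the one measured step (a step that the two limits leave unreadable from compound 1 to compound 2) put fluoro in place of hydrogen on an aromatic carbon and offers no size to carry over, with the limit of > 10000 nM in this assay, at which 2 of the 2 values shown sit, as the evidence. No change beyond the scatter is therefore expected (a step that the limit leaves unreadable from compound 2 to compound 3). Compound 3 is estimated at 15000 nM in this assay with an expected range from 8000 nM to 40000 nM in that test.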

Compound 3, half-maximal cytotoxic concentration: > 10000 nM
Compound 3: only a limit was reported; the forecaster's own chance of this, stated with the estimate: 85%; the middle value lies beyond the limit too.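

Within the data shown here, compound 1, compound 2 and compound 3 each give only a limit, not a number, so no step among them can be read. Going by these compounds, whether hydrogen, fluoro or chloro on the aromatic ring changes cytotoxicity beyond that limit stays open.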